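Ethyl to Isopropyl Ester on Two Related Cores

This account rests on a few compounds, and the source may have more. Where it says the series, first, only, none or still open, it means among the compounds named here.

Four compounds share a furan-bearing core and differ in two spots. Compound 1 `CCOC(=O)C1=C(C)NC(=S)NC1c1ccoc1` and compound 2 `CC1=C(C(=O)OC(C)C)C(c2ccoc2)NC(=S)N1` carry the same core; compound 2 arises from compound 1 by methyl in place of hydrogen on a saturated chain carbon bound to an oxygen next to a carbonyl group and a saturated chain carbon. In an assay on HeLa cells for displacement of a labelled ligand from adenosine receptor A3 (Homo sapiens), with a stated time of 180 min, tested at 10 uM (a lower number here means less inhibition, a higher number more inhibition at the concentration tested (going by the name of the read-out)), compound 1 gives 15% and compound 2 gives 23%, a step of a number 8 percentage points higher from compound 1 to compound 2 (within the scatter). Compound 3 `CCOC(=O)C1=C(C)N(C)C(=O)NC1c1ccoc1` sits on a second core; the difference between the two cores is not broken down here. In this assay compound 3 gives 1%, the lowest of the three numbers. Compound 4 `CC1=C(C(=O)OC(C)C)C(c2ccoc2)NC(=O)N1C`, not yet measured, arises from compound 3 by methyl in place of hydrogen on a saturated chain carbon bound to an oxygen next to a carbonyl group and a saturated chain carbon, the same change that leads from compound 1 to compound 2. The step from compound 3 to compound 4 is expected to be about a number 4 percentage points higher from compound 3 to compound 4 (within the scatter), small, because the earlier step was a number 8 percentage points higher from compound 1 to compound 2 (within the scatter). Compound 4 is therefore estimated at 5%, with a likely span from -5% to 15%. This rests on compound 3, which gives 1%, and on the modest earlier step.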

Compound 4, a percentage reported as inhibition, at one concentration (the size of the read-out at that concentration, not a potency): 1%
Beside the measured number, compound 4's estimate is 4 percentage points above it, and the stated range covers the measured number.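

In this assay, replacing ethyl with isopropyl on the second core gives no change at the digits printed from compound 3 to compound 4 (within the scatter), and compound 4 stays at 1%. Set beside the matching step on the first core, the two results cannot be told apart: the same change on two cores in this assay, a number 8 percentage points higher (within the scatter) from compound 1 to compound 2 and no change at the digits printed (within the scatter) from compound 3 to compound 4, 8 percentage points apart, within the scatter of two such steps

This shows that, on these two cores, the change from ethoxycarbonyl to isopropoxycarbonyl gives no step beyond the scatter, so the small result carries over from one core to the other within what this measurement can resolve. It does not show that the change has no effect or that both cores respond identically, as a small real difference could stay hidden in the scatter, and a single tested concentration gives no potency.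

The compounds shown leave open what a longer chain in place of the isopropyl would do, or a carboxylic acid in place of the ester. Also open, from the compounds shown here alone, is what each difference between the two cores does on its own.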